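A few compounds are considered here, and "the series" means these few. Any claim that something is new, unique, unknown or untested is made for them only; others in the source may bear on it.

Measured compounds:
- compound 1 `COc1ccc(-c2cc(/C=C/C(=O)c3ccc(N)cc3)[nH]n2)cc1` — 61200 nM
- compound 2 `COc1ccc(C(=O)/C=C/c2cc(-c3cc(OC)c(OC)c(OC)c3)n[nH]2)cc1` — 8070 nM

In a functional assay on HOP-62 cells (Homo sapiens) for inhibition, read by sulforhodamine B assay, with a stated time of 48 h (on this read-out lower numbers stand for higher toxicity in this test and higher numbers for lower toxicity in this test), compound 1 gives 61200 nM, the highest of the two numbers. Within the data shown here, the only other measured compound, compound 2, gives 8070 nM in this assay, a lower number, beyond the scatter; compound 2 differs from compound 1 in more than one place, so no single step can be read from that pair.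

Compound 3 `COc1ccc(-c2cc(/C=C/C(=O)c3ccc(N)cc3)[nH]n2)cc1OC` has not yet been measured. It differs from compound 1 as follows: methoxy in place of hydrogen on an aromatic carbon — methoxy in place of hydrogen on an aromatic carbon. Among the measured compounds shown here, no step between measured compounds shows what such a change does to the core of compound 1.

For this assay a modest step is expected, towards a lower number, though it may well stay within the scatter. The estimate for compound 3 is 35000 nM, with a range of 12000 nM to 90000 nM. The step this estimate means, a 1.7-fold lower number from compound 1 to compound 3 (0.24 log units; within the scatter), is expected to be small given that nothing measured anchors it.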

Compound 3, concentration lethal to 50% of the cells: 32000 nM
The estimate for compound 3 lay 1.1-fold (0.04 log units) above the measured number, and the stated range covers the measured number.
By their numbers in this assay, from the lowest: compound 2; then compounds 3 and 1 (each within the scatter of the next).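

In this assay, methoxy in place of hydrogen on an aromatic carbon, at the place ortho to a methoxy group and meta to a large group, gives a 1.9-fold lower number from compound 1 to compound 3 (0.28 log units; within the scatter). Among these compounds, this is the first single-place step, and it shows that at this position on the core of compound 1, this change leaves the two numbers indistinguishable in this test, which the comparison with compound 2, differing in more than one place, could not show. Nothing measured on these compounds accounts for the size of this step.

Still open, on these data alone, is whether a different group at this same place, such as a hydroxyl, a fluorine, an amine or a longer alkoxy chain, would give a step beyond the scatter, or whether this position stays as flat for groups other than methoxy. Also open, as far as these compounds go, is how much of the number of compound 2 can be traced to any single one of the places in which it differs from compound 1, since a single step from the shared core reads only one of them.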